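Ester-to-ketone switch on the carbonyl of the shared core

This account rests on a few compounds, and the source may have more. Where it says the series, first, only, none or still open, it means among the compounds named here.

Compound 1 `Cc1ncsc1CCOC(=O)c1oc2cc(-c3ccccc3)cc(O)c2c1C` gives 0.055 ug/mL in a functional assay on WI-38 VA13 cells (Homo sapiens) for cytotoxicity (a lower number here means that less compound is needed, a higher number that more compound is needed for the effect), and stands highest of the three numbers. Compound 2 `COc1ccc(CCOC(=O)c2oc3cc(-c4ccccc4)cc(O)c3c2C)cc1OC` gives 0.021 ug/mL and compound 3 `COc1ccc(CCOC(=O)c2oc3cc(-c4ccccc4)cc(O)c3c2C)cc1` gives 0.02 ug/mL in this assay. The step of a 2.6-fold lower number from compound 1 to compound 2 (0.42 log units; beyond the scatter) and the step of a 2.8-fold lower number from compound 1 to compound 3 (0.44 log units; beyond the scatter) both replace the thiazolyl group on the ethyl chain with an aryl group and both lower the number beyond the scatter; the step of a 1.1-fold lower number from compound 2 to compound 3 (0.02 log units; within the scatter) shows nothing beyond the scatter.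

Compound 4 `CCc1ccc(C(=O)c2oc3cc(-c4ccccc4)cc(O)c3c2C)cc1` carries 4-ethylphenyl in place of 2-(4-methyl-1,3-thiazol-5-yl)ethoxy on a carbonyl carbon. Among the measured compounds shown here, this removes the thiazole, as the measured steps do, but also removes the ethoxy link, so that an aryl ketone replaces the ester; no measured pair covers that part. The two steps from compound 1 point toward a lower number, and the unmeasured part of the change widens the range rather than the direction. For compound 4 a step of a 1.6-fold lower number from compound 1 to compound 4 (0.20 log units; within the scatter) in this assay is therefore expected, within the scatter or modestly lower. The estimate for compound 4 is 0.035 ug/mL, in the range 0.01 ug/mL to 0.12 ug/mL.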

Compound 4, half-maximal effective concentration: > 4 ug/mL
Compound 4: no number, only a limit; the forecaster's own chance of this, stated with the estimate: 5%; middle value at least 110-fold (2.05 log units) away from the limit.
By their numbers in this assay, from the lowest: compounds 3 and 2 (each within the scatter of the next); then compound 1. At a limit, above all of these: compound 4.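

Compound 4 gives a limit, not a number, in this assay: the limit of > 4 ug/mL in this assay, at which 1 of the 4 values shown sits.

The step of an at least 72-fold higher number from compound 1 to compound 4 (1.86 log units; beyond the scatter) runs against the steps of a 2.6-fold lower number from compound 1 to compound 2 (0.42 log units; beyond the scatter) and a 2.8-fold lower number from compound 1 to compound 3 (0.44 log units; beyond the scatter), in which aryl groups replace the thiazolyl group while the ester and ethyl chain stay. Among the compounds shown here, on this carbonyl carbon, then, an aromatic ring in place of the thiazole does not by itself raise the number; the large rise appears only in the single change that also turns the ester into an aryl ketone, and this one step cannot separate the loss of the ester link from the loss of the chain.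

From the compounds shown here alone, it remains open whether an amide with the same 2-arylethyl chain would stay close to compounds 1 to 3. The same holds for a ketone keeping that ethyl chain, or for a free carboxylic acid on this carbonyl carbon.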